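Swapping Bromo for Iodo in Compound 1

The source may hold more compounds than are shown below. What is called first, only, known or untested is meant among the compounds shown, and "the series" means these compounds.

In a functional assay on PC-3 cells (Homo sapiens) for antiproliferative activity, with a stated time of 48 h (on this read-out higher numbers stand for weaker inhibition and lower numbers for stronger inhibition), compound 1 (`COc1ccc(C(=O)/C=C/c2ccccc2)c(O)c1Br`) gives 47800 nM, the higher of the two numbers available. Compound 3 (`CCCOc1ccc(C(=O)/C=C/c2ccccc2)c(O)c1`) gives 8080 nM, lower by more than the scatter. Compound 2 (`COc1cc(O)c(C(=O)/C=C/c2ccccc2)cc1I`) is reported only as a limit, > 50000 nM. Compound 4 (`COc1ccc(C(=O)/C=C/c2ccccc2)c(O)c1I`) carries iodo in place of bromo on an aromatic carbon, ortho to a hydroxy group and ortho to a methoxy group: iodo in place of bromo on an aromatic carbon. For the measured compounds named here, no measured step tests this exchange, so no change beyond the scatter is expected in this assay. Like compound 2, compound 4 may also be reported only as a limit. The expected step is a 1.1-fold lower number from compound 1 to compound 4 (0.06 log units; within the scatter). For compound 4, the estimated value is 42000 nM, with an expected range of 20000 nM to 50000 nM.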

Compound 4, half-maximal inhibitory concentration: 34000 nM
For compound 4 the middle estimate is 1.2-fold (0.09 log units) above the measured one, within the range that was stated.
By their numbers in this assay, from the lowest: compound 3; then compounds 4 and 1 (each within the scatter of the next). At a limit, above all of these: compound 2.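

On an aromatic carbon ortho to a hydroxy group and ortho to a methoxy group, iodo in place of bromo now has a measured step, a 1.4-fold lower number from compound 1 to compound 4 (0.15 log units; within the scatter), so in this assay this exchange leaves the read-out unchanged within the scatter. With iodo at this position, compound 4 still gives a number rather than a limit. Compound 2, by contrast, is reported only as a limit: the limit of > 50000 nM in this assay, at which 1 of the 4 values shown sits.

Going by these compounds, how chloro, an amine or a carboxylic acid at this position would read stays open. On these data alone, whether any group here can move the number beyond the scatter also remains unknown.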